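From methyl to (methoxycarbonyl)methyl on compound 3

This account rests on a few compounds, and the source may have more. Where it says the series, first, only, none or still open, it means among the compounds named here.

Measured in a functional assay on K562 cells (Homo sapiens) for inhibition, read by trypan blue exclusion, with a stated time of 72 h; a lower number here means a stronger inhibitor, a higher number a weaker inhibitor:
Compound 1 `Cn1c(=O)c(S(=O)(=O)c2ccc(F)cc2F)cc2cnc(Nc3ccncn3)nc21`: 30000 nM
Compound 2 `Cn1c(=O)c(S(=O)(=O)c2ccc(F)cc2F)cc2cnc(Nc3ccc4[nH]ncc4c3)nc21`: 50000 nM
Compound 3 `Cn1ccc2cc(Nc3ncc4cc(S(=O)(=O)c5ccc(F)cc5F)c(=O)n(C)c4n3)ccc21`: 750 nM

Compound 3 has the lowest number of the three. Two large measured steps lead to it: a 40-fold lower number from compound 1 to compound 3 (1.60 log units; beyond the scatter) and a 67-fold lower number from compound 2 to compound 3 (1.82 log units; beyond the scatter). By contrast, a 1.7-fold higher number from compound 1 to compound 2 (0.22 log units; within the scatter). Compound 4 `COC(=O)Cn1ccc2cc(Nc3ncc4cc(S(=O)(=O)c5ccc(F)cc5F)c(=O)n(C)c4n3)ccc21` differs from compound 3 by methoxycarbonyl in place of hydrogen on a saturated chain carbon bound to an aromatic nitrogen. For the measured compounds named here, the two large steps exchanged the whole group on a nitrogen on an aromatic ring, and no measured step alters this chain. They therefore give only loose guidance, and a modest move to a higher number is expected in this assay. The expected step is a 2.4-fold higher number from compound 3 to compound 4 (0.38 log units; beyond the scatter). For compound 4 the estimated value is 1800 nM, within an expected range of 350 nM to 9000 nM.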

Compound 4, half-maximal inhibitory concentration: 5000 nM
For compound 4 the middle estimate is 2.8-fold (0.44 log units) below the measured one, and the stated range covers the measured number.
By their numbers in this assay, from the lowest: compound 3; then compound 4; then compounds 1 and 2 (each within the scatter of the next).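

In this assay, for the compounds shown here, the first measured change to this chain, rather than to the whole group on a nitrogen on an aromatic ring, gives a 6.7-fold higher number from compound 3 to compound 4 (0.82 log units; beyond the scatter). The methyl to (methoxycarbonyl)methyl change therefore weakens the compound measurably, though the step is modest beside the large exchanges of the whole group. Nothing measured here accounts for this shift.

A single ester cannot show whether the loss belongs to the added carbonyl or to the added length. As far as these compounds go, a carboxylic acid, an amine or a longer chain at this place remains open.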